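Swapping the Trimethoxyphenyl Arm for a Dichlorophenyl Arm

The compounds below may be only part of what the source reports. "The series", "measured", "known", "first", "only" and "open" are said of these compounds alone.

Three compounds share one core and differ only in the aryl group carried on a nitrogen attached to an aromatic ring. Compound 1 `C=CC(=O)Nc1cccc(NC(=O)CSc2nc(Nc3ccccc3Cl)c3ccccc3n2)c1` bears a 2-chlorophenyl there and in a functional assay on MDA-MB-231 cells (Homo sapiens) for inhibition, read by MTT assay, with a stated time of 72 h (on this read-out lower numbers stand for stronger inhibition and higher numbers for weaker inhibition), compound 1 gives 12700 nM. Compound 2 `C=CC(=O)Nc1cccc(NC(=O)CSc2nc(Nc3ccccc3C)c3ccccc3n2)c1` carries a 2-methylphenyl, and in this assay compound 2 gives 20400 nM; the step of a 1.6-fold higher number from compound 1 to compound 2 (0.21 log units; within the scatter) separates them. Compound 3 `C=CC(=O)Nc1cccc(NC(=O)CSc2nc(Nc3cc(OC)c(OC)c(OC)c3)c3ccccc3n2)c1` carries a 3,4,5-trimethoxyphenyl, and in this assay compound 3 gives > 50000 nM, which is a limit of the assay and not a measured number (the limit of > 50000 nM in this assay, at which 1 of the 3 values shown sits). Compound 3 therefore stands weakest among the three as far as the numbers show: the step of an at least 3.9-fold higher number from compound 1 to compound 3 (0.59 log units; beyond the scatter) and the step of an at least 2.4-fold higher number from compound 2 to compound 3 (0.38 log units; beyond the scatter) both lie beyond the scatter.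

Compound 4 `C=CC(=O)Nc1cccc(NC(=O)CSc2nc(Nc3ccc(Cl)cc3Cl)c3ccccc3n2)c1` is not yet measured. It differs from compound 3 by 2,4-dichlorophenyl in place of 3,4,5-trimethoxyphenyl on a nitrogen on an aromatic ring. The two steps that end at compound 3 bear on this change, since both replaced a small ortho-substituted phenyl by the trimethoxyphenyl and both raised the number. Going back to a chlorine-bearing phenyl, the expectation is a lowered number, a step estimated as an at least 4.1-fold lower number from compound 3 to compound 4 (0.61 log units; beyond the scatter). For compound 4 in this assay the estimate is 12000 nM, within a range from 4000 nM to 40000 nM.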

Compound 4, half-maximal inhibitory concentration: 23100 nM
Compound 4: the middle estimate sits 1.9-fold (0.28 log units) below what was measured; the measured number falls inside the stated range.
By their numbers in this assay, from the lowest: compounds 1, 2 and 4 (each within the scatter of the next). At a limit, above all of these: compound 3.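

In this assay, the change to 2,4-dichlorophenyl gives an at least 2.1-fold lower number from compound 3 to compound 4 (0.33 log units; beyond the scatter) and so shows that a second chlorine-bearing arm, one with two chlorines, also reads lower than the 3,4,5-trimethoxyphenyl arm. As far as these compounds go, the starting point of that step is a limit for compound 3 and not a measured number, so the true size of the step is unknown: the limit of > 50000 nM in this assay, at which 1 of the 4 values shown sits. Against the other two arms, the new compound shows a 1.8-fold higher number from compound 1 to compound 4 (0.26 log units; within the scatter) and a 1.1-fold higher number from compound 2 to compound 4 (0.05 log units; within the scatter), so neither adding a chloro in place of hydrogen on an aromatic carbon nor exchanging the 2-methylphenyl for the 2,4-dichlorophenyl moves the number beyond the scatter, and these three compounds cannot be ranked against one another.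

The compounds shown cannot say whether it is the three methoxy groups together that set compound 3 apart, and a phenyl carrying one methoxy group would help to separate that question. Nor do they tell how this nitrogen would tolerate an arm carrying an amine or a carboxylic acid, or a saturated ring such as cyclohexyl in place of the phenyl.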